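From a Cyclobutyl Ester to a Cyclohexyl Ester

This account rests on a few compounds, and the source may have more. Where it says the series, first, only, none or still open, it means among the compounds named here.

Measured so far:
compound 1 `CC1=C(C(=O)CC(C)C)C(c2ccoc2)NC(=O)N1` gives 23%
compound 2 `CC1=C(C(=O)OC2CCC2)C(c2ccoc2)NC(=O)N1` gives 20%

Both numbers come from an assay on membranes from CHO cells for displacement of a labelled ligand from adenosine receptor A1 (Homo sapiens), read by scintillation counting, with a stated time of 60 min, tested at 1 uM; a lower number here means less inhibition, a higher number more inhibition at the concentration tested (going by the name of the read-out). Going by the values given here, compound 2 stands close to compound 1 on these numbers: the only measured step, a number 3 percentage points lower from compound 1 to compound 2 (within the scatter), replaces isobutyl with cyclobutyloxy on a carbonyl carbon and stays within the scatter.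

Compound 3 `CC1=C(C(=O)OC2CCCCC2)C(c2ccoc2)NC(=O)N1` is not yet measured. It differs from compound 2 by cyclohexyl in place of cyclobutyl on an oxygen next to a carbonyl group. Among the compounds with values here, no measured step swaps one carbon ring for another on the ester oxygen, so nothing here speaks directly to this change. Within the data shown here, the one step that exists, from compound 1 to compound 2, touched the same carbonyl and moved the number only within the scatter, which gives no reason to expect a large shift in this assay from compound 2 to compound 3.

Compound 3 is therefore expected to lie near compound 2, with an estimated step of a number 2 percentage points higher from compound 2 to compound 3 (within the scatter). The estimate for compound 3 is 22%, with a range from 5% to 42%.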

Compound 3, a percentage reported as inhibition, at one concentration (the size of the read-out at that concentration, not a potency): 15%
Compound 3: the middle estimate sits 7 percentage points above what was measured, within the range that was stated.
By their numbers in this assay, from the lowest: compounds 3, 2 and 1 (each within the scatter of the next).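

The step of a number 5 percentage points lower from compound 2 to compound 3 (within the scatter) is the first shown that swaps one carbon ring for another on the ester oxygen, and in this assay it stays within the scatter. Set against the isobutyl group on the carbonyl carbon, the cyclohexyloxy group gives a number 8 percentage points lower from compound 1 to compound 3 (within the scatter), also within the scatter, so none of the three groups at this carbonyl stands apart from the others on these numbers. Nothing measured here offers an explanation for how close these numbers lie.

Going by these compounds, whether an amine or a carboxylic acid in place of the cyclohexyl ring would give a clearly different number remains open. On these data alone, since each compound is read at one concentration only, their potencies also remain open.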